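The compounds below may be only part of what the source reports. "The series", "measured", "known", "first", "only" and "open" are said of these compounds alone.

Working notes on the series. Three compounds have been run in an ADME assay on microsomes from liver (Homo sapiens) for metabolic stability, tested at 2.5 uM; a higher number here means faster removal of the compound, a lower number slower removal. Compound 1 `O=S(=O)(c1cccc(F)c1)c1cnc2c(F)cccc2c1-c1ccc(Cl)cc1` gives 0.62 mL/min in this assay. Compound 2 `O=S(=O)(c1cc(F)cc(F)c1)c1cnc2c(F)cccc2c1-c1ccc(Cl)cc1` gives 0.73 mL/min in this assay. Compound 3 `O=S(=O)(c1ccc(F)c(F)c1)c1cnc2cc(F)ccc2c1-c1cccc(F)c1` gives 0.6 mL/min in this assay. Compounds 2 and 1 differ in one place: hydrogen in place of fluoro on an aromatic carbon. The step is a 1.2-fold lower number from compound 2 to compound 1 (0.07 log units; within the scatter). Compound 3 sits on a different core from compound 2; the difference between the two cores is not broken down here, and the two values are simply taken as they stand.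

Compound 4 `O=S(=O)(c1cccc(F)c1)c1cnc2cc(F)ccc2c1-c1cccc(F)c1` has not yet been run in this assay. It differs from compound 3 by hydrogen in place of fluoro on an aromatic carbon. This is the same kind of change as that from compound 2 to compound 1, not the same change: in compound 1 the hydrogen enters meta to a fluoro group and meta to a large group, whereas in compound 4 it enters ortho to a fluoro group and para to a large group. The change occurs twice among the compounds shown, and only the earlier instance is measured.

The expected step in this assay is a 1.1-fold lower number from compound 3 to compound 4 (0.04 log units; within the scatter), set beside the measured 1.2-fold lower number from compound 2 to compound 1 (0.07 log units; within the scatter). That expectation rests on the earlier instance, where the step of a 1.2-fold lower number from compound 2 to compound 1 (0.07 log units; within the scatter) was within the scatter, and on compound 3 at 0.6 mL/min. Compound 4 is expected to come in at about 0.55 mL/min in this assay. The range for compound 4 is estimated from 0.35 mL/min to 0.9 mL/min.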

Compound 4, intrinsic clearance in a liver preparation (reported as CLH), per the amount of preparation that the assay uses: 0.24 mL/min
Compound 4: the middle estimate sits 2.3-fold (0.36 log units) above what was measured; the measured number lies below the stated range.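

In this assay, going from 3,4-difluorophenyl to 3-fluorophenyl gives a 2.5-fold lower number from compound 3 to compound 4 (0.40 log units; beyond the scatter), while the earlier replacement of fluoro by hydrogen on the other core gave a 1.2-fold lower number from compound 2 to compound 1 (0.07 log units; within the scatter). Set side by side, the two steps cannot be told apart: the same change on two cores in this assay, a 1.2-fold lower number (0.07 log units; within the scatter) from compound 2 to compound 1 and a 2.5-fold lower number (0.40 log units; beyond the scatter) from compound 3 to compound 4, 2.1-fold (0.33 log units) apart, within the scatter of two such steps. Among the compounds shown here, the new step alone lies beyond the scatter, but the pair of steps does not show that the core sets the size of this change, nor does it establish one size that carries from core to core, since only two pairs are available and the fluoro leaves from a different place on the ring in each.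

On these data alone, it remains open whether the step seen for compound 4 would recur if the same 3,4-difluorophenyl to 3-fluorophenyl change were placed on the core of compound 1. The aromatic substituents shown are limited to fluoro and chloro, so it is also open how this assay would read with a methoxy group, a nitrile or an amine in place of the fluoro that leaves.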